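This account rests on a few compounds, and the source may have more. Where it says the series, first, only, none or still open, it means among the compounds named here.

Within the data shown here, in a functional assay, read by spectrophotometry, with a stated time of 5 min (on this read-out lower numbers stand for stronger inhibition and higher numbers for weaker inhibition), compound 3 (`N/N=C\c1cc(=O)oc2cc(OCc3ccccc3)cc(OCc3ccccc3)c12`) gives 36500 nM and holds the lower of the two true numbers so far. Compound 2 (`Nc1ccccc1/N=C\c1cc(=O)oc2cc(OCc3ccccc3)cc(OCc3ccccc3)c12`) gives 258000 nM as its number. Compound 1 (`O=c1cc(/C=N\O)c2c(OCc3ccccc3)cc(OCc3ccccc3)cc2o1`) reads > 2000000 nM and this is a limit of the assay. Compound 4 (`N/N=C\c1cc(=O)oc2cc(OCc3ccccc3)ccc12`) differs from compound 3 by one change (hydrogen in place of benzyloxy on an aromatic carbon), hydrogen in place of benzyloxy on an aromatic carbon. The measured steps, such as an at least 54-fold lower number from compound 1 to compound 3 (1.73 log units; beyond the scatter) and a 7.1-fold lower number from compound 2 to compound 3 (0.85 log units; beyond the scatter) and an at least 7.7-fold lower number from compound 1 to compound 2 (0.88 log units; beyond the scatter) as well, all alter the group on the double-bonded nitrogen, so none tests this place. A modest rise in this assay is therefore expected, only loosely, as a 1.6-fold higher number from compound 3 to compound 4 (0.22 log units; within the scatter) in the estimate. For compound 4 the estimate is 60000 nM with an expected range from 12000 nM to 300000 nM overall.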

Compound 4, half-maximal inhibitory concentration: 131000 nM
For compound 4 the middle estimate is 2.2-fold (0.34 log units) below the measured one; measured number inside the range.
By their numbers in this assay, from the lowest: compound 3; then compounds 4 and 2 (each within the scatter of the next). At a limit, above all of these: compound 1.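

In this assay, putting hydrogen in place of benzyloxy on an aromatic carbon gives a 3.6-fold higher number from compound 3 to compound 4 (0.55 log units; beyond the scatter), so inhibition weakens. Among these compounds, this is the first step that leaves the double-bonded nitrogen untouched, and it shows that the benzyloxy group at this place, ortho to a fused ring, contributes to the inhibition seen with compound 3. Nothing measured here explains the size of this step. From the compounds shown here alone, whether a smaller group, such as methoxy or hydroxy, would retain the inhibition of compound 3 remains open. So does the effect of a chlorine atom at this place.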